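Removing one chloro from the shared core: a second test

A few compounds are considered here, and "the series" means these few. Any claim that something is new, unique, unknown or untested is made for them only; others in the source may bear on it.

Compound 1, `ClCc1ccccc1Cn1cnc2c(Cl)nc(Cl)nc21`, is measured in a functional assay on UACC-257 cells (Homo sapiens) for cytotoxicity, read by sulforhodamine B assay, with a stated time of 48 h (a lower number here means that less compound is tolerated, a higher number that more compound is tolerated), where compound 1 gives 8510 nM. Compound 2, `ClCc1ccccc1Cn1cnc2c(Cl)ncnc21`, differs from it by one change, (hydrogen in place of chloro on an aromatic carbon), and in this assay compound 2 gives 66100 nM. That single change made a step of a 7.8-fold higher number from compound 1 to compound 2 (0.89 log units; beyond the scatter).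

Compound 3, `ClCc1ccc(Cn2cnc3nc(Cl)nc(Cl)c32)cc1`, has the same atoms as compound 1 joined differently; the difference between the two cores is not broken down here. In this assay compound 3 gives 34700 nM, which stands close to the value of compound 2 and well apart from the value of compound 1.

Compound 4, `ClCc1ccc(Cn2cnc3ncnc(Cl)c32)cc1`, is not yet measured. It arises from compound 3 by hydrogen in place of chloro on an aromatic carbon. Going by the values given here, this is the same change as the one from compound 1 to compound 2, at a place described in the same words, so the only guide to its effect is the step of a 7.8-fold higher number from compound 1 to compound 2 (0.89 log units; beyond the scatter) seen on the core of compound 1. Among the compounds with values here, whether the core of compound 3 answers the change in the same way is unknown, because only one example of this change has been measured.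

On that basis a step of about a 5.8-fold higher number from compound 3 to compound 4 (0.76 log units; beyond the scatter) is expected from compound 3 to compound 4. Compound 4 is therefore estimated at 200000 nM in this assay, with a plausible range from 60000 nM to 500000 nM, the wide range reflecting that the expectation rests on a single measured step.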

Compound 4, concentration lethal to 50% of the cells: 7760 nM
For compound 4 the middle estimate is 26-fold (1.41 log units) above the measured one, and the stated range ends above it.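

In this assay, replacing the chloro group that lies between two ring nitrogen atoms with hydrogen gave a 4.5-fold lower number from compound 3 to compound 4 (0.65 log units; beyond the scatter), so the number moved in the opposite direction to the earlier example. Set side by side, the two results show that this change does not carry over from one core to the other in this series, either in direction or in size: the same change on two cores in this assay, a 7.8-fold higher number (0.89 log units; beyond the scatter) from compound 1 to compound 2 and a 4.5-fold lower number (0.65 log units; beyond the scatter) from compound 3 to compound 4, 35-fold (1.54 log units) apart, beyond the scatter of two such steps. They do not show why the two cores part ways, and two examples cannot tell which result is more typical or how the change would behave on any further core.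

The compounds shown carry only chloro or hydrogen at this place, so it remains open how an amine or a methoxy group there would fare on either core. All four also keep their chloromethyl group, which leaves open whether a hydroxymethyl or plain methyl group in its place would alter these numbers or the opposite behaviour of the two cores.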